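Swapping (trifluoromethyl)sulfanyl for trifluoromethyl on the shared core

The source may hold more compounds than are shown below. What is called first, only, known or untested is meant among the compounds shown, and "the series" means these compounds.

In a functional assay on MCF7 cells (Homo sapiens) for inhibition, read by MTT assay, with a stated time of 72 h (a higher number here means a weaker inhibitor, a lower number a stronger inhibitor), compound 1 (`NS(=O)(=O)c1ccc2c(c1)C(=O)C(=O)N2Cc1cccc(C(F)(F)F)c1`) gives 5900 nM and compound 2 (`NS(=O)(=O)c1ccc2c(c1)C(=O)C(=O)N2Cc1ccc(SC(F)(F)F)cc1`) gives 3200 nM. These two values lie within the usual scatter of each other, so compound 2 stands level with compound 1. Compound 3 (`NS(=O)(=O)c1ccc2c(c1)C(=O)C(=O)N2Cc1ccc(C(F)(F)F)cc1`) differs from compound 2 in one place, with trifluoromethyl in place of (trifluoromethyl)sulfanyl on an aromatic carbon, para to a large group (trifluoromethyl in place of (trifluoromethyl)sulfanyl on an aromatic carbon). Among the measured compounds shown here, no measured step shows this change on its own. The nearest guide is compound 1, which also carries trifluoromethyl and gives 5900 nM, while compound 2 gives 3200 nM. In this assay, the expected 1.4-fold higher number from compound 2 to compound 3 (0.15 log units; within the scatter) is small, leaning towards a higher number and staying within the scatter. For compound 3, the estimated value is 4500 nM, with an expected range from 1800 nM to 11000 nM.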

Compound 3, half-maximal inhibitory concentration: 5500 nM
The estimate for compound 3 lay 1.2-fold (0.09 log units) below the measured number; the range from low to high includes it.
By their numbers in this assay, from the lowest: compounds 2, 3 and 1 (each within the scatter of the next).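

In this assay, among the compounds shown here, the swap at this position shows a 1.7-fold higher number from compound 2 to compound 3 (0.24 log units; within the scatter) and is the first direct reading of trifluoromethyl against (trifluoromethyl)sulfanyl on an aromatic carbon, para to a large group. Compound 1 and compound 2 could not give this reading, as their groups differ in both identity and place on the shared core. On this core and at this position the two groups stand level, and nothing at hand offers a reason for that.

The compounds shown leave open whether a group of another kind at this position, such as an amine, a carboxylic acid or a longer chain, would stand apart from these two in this assay at all. They also leave open whether the same swap would read alike on a different core.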